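The source may hold more compounds than are shown below. What is called first, only, known or untested is meant among the compounds shown, and "the series" means these compounds.

Measured in a physicochemical assay, read by spectrophotometry, with a stated time of 6 min; on this read-out higher numbers stand for weaker inhibition and lower numbers for stronger inhibition:
- Compound 1 `O=C(CCc1nc2ccccc2c(=O)[nH]1)N/N=C/c1ccc([N+](=O)[O-])cc1`: 220000000 nM
- Compound 2 `COc1cc(/C=N/NC(=O)CCCc2nc3ccccc3c(=O)[nH]2)ccc1O`: 115000000 nM
- Compound 3 `O=C(CCc1nc2ccccc2c(=O)[nH]1)N/N=C/c1cc(O)c(O)c(O)c1`: 35000000 nM

Compound 2 at 115000000 nM lies within the usual scatter of compound 1 at 220000000 nM, while compound 3 at 35000000 nM reads clearly lower. Compound 4 `O=C(CCCc1nc2ccccc2c(=O)[nH]1)N/N=C/c1ccc(O)c(O)c1` is made from compound 2 by one change: hydrogen in place of methyl on an oxygen on an aromatic ring, so methoxy becomes hydroxy. For the measured compounds named here, no measured step makes this exact change. The nearest, a 6.3-fold lower number from compound 1 to compound 3 (0.80 log units; beyond the scatter), puts 3,4,5-trihydroxyphenyl in place of 4-nitrophenyl, so it offers only loose guidance toward a lower number. A smaller shift is therefore expected in this assay, and the expected step is a 2.3-fold lower number from compound 2 to compound 4 (0.36 log units; beyond the scatter). For compound 4 the estimate is 50000000 nM, within a range of 20000000 nM to 120000000 nM.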

Compound 4, half-maximal inhibitory concentration: 50000000 nM
Estimate against measurement, compound 4: no gap at the digits printed; measured number inside the range.
By their numbers in this assay, from the lowest: compounds 3 and 4 (each within the scatter of the next); then compounds 2 and 1 (each within the scatter of the next).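

In this assay, swapping methoxy for hydroxy gives a 2.3-fold lower number from compound 2 to compound 4 (0.36 log units; beyond the scatter) and turns 4-hydroxy-3-methoxyphenyl into 3,4-dihydroxyphenyl while the rest of the molecule stays the same. This shows that one group on this ring oxygen can shift the number on its own, whereas the earlier step replaced the whole ring pattern at once. No measurement here explains why this change has this effect.
Still open, as far as these compounds go, is how a larger ethoxy group on that oxygen would read, or an amine in place of the hydroxy group.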